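A chloro for fluoro exchange on the aromatic ring

This account rests on a few compounds, and the source may have more. Where it says the series, first, only, none or still open, it means among the compounds named here.

Compound 1 `COc1ccc(-c2nnc(SCc3ccc(Cl)nc3)o2)cc1`: 3.5 ug/mL
Compound 2 `CCOc1ccc(-c2nnc(SCc3ccc(Cl)nc3)o2)cc1`: 4.97 ug/mL
Compound 3 `Fc1ccc(-c2nnc(SCc3ccc(Cl)nc3)o2)cc1`: 3.67 ug/mL

In a functional assay on SGC-7901 cells (Homo sapiens) for antiproliferative activity, read by MTT assay, with a stated time of 48 h (on this read-out higher numbers stand for weaker inhibition and lower numbers for stronger inhibition), compound 3 gives 3.67 ug/mL, a value that does not separate it from the other two compounds. Compound 4 `Clc1ccc(-c2nnc(SCc3ccc(Cl)nc3)o2)cc1` differs from it by one exchange, (chloro in place of fluoro on an aromatic carbon), which is chloro in place of fluoro on an aromatic carbon. Among the measured compounds shown here, no measured step brings in chloro, so the evidence is indirect. Two steps change the group on that same aromatic carbon, a 1.0-fold higher number from compound 1 to compound 3 (0.02 log units; within the scatter) and a 1.4-fold lower number from compound 2 to compound 3 (0.13 log units; within the scatter), and both stayed small. The remaining step, a 1.4-fold higher number from compound 1 to compound 2 (0.15 log units; within the scatter), changes only the chain on the oxygen and was also small. On these steps, no change beyond the scatter is expected in this assay, and no direction can be favoured. The estimated change is a 1.0-fold higher number from compound 3 to compound 4 (0.00 log units; within the scatter). The value expected for compound 4 is 3.7 ug/mL, with an estimated range from 2 ug/mL to 6.8 ug/mL.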

Compound 4, half-maximal inhibitory concentration: 8.62 ug/mL
For compound 4 the middle estimate is 2.3-fold (0.37 log units) below the measured one; the whole stated range lies below it.
By their numbers in this assay, from the lowest: compounds 1, 3, 2 and 4 (each within the scatter of the next, the first and the last beyond it).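

In this assay the change from 4-fluorophenyl to 4-chlorophenyl gives a 2.3-fold higher number from compound 3 to compound 4 (0.37 log units; beyond the scatter) and so shows that this aromatic carbon can respond to a single-atom exchange, which none of the earlier steps at this carbon had shown. Chloro in place of methoxy also goes beyond the scatter with a 2.5-fold higher number from compound 1 to compound 4 (0.39 log units; beyond the scatter), while chloro in place of ethoxy gives a 1.7-fold higher number from compound 2 to compound 4 (0.24 log units; within the scatter) and stays within it, so compound 4 separates from only two of the other three compounds. Nothing available explains why chloro behaves this way here.

The compounds shown leave open whether a bromo, a trifluoromethyl or an amine on this carbon would group with chloro or with fluoro. As far as these compounds go, it also remains open whether the chloro for fluoro step would recur with a longer chain elsewhere on the shared core.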